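From Acetoxy to Acetoxymethyl on a Saturated Chain

The compounds below may be only part of what the source reports. "The series", "measured", "known", "first", "only" and "open" are said of these compounds alone.

Of the compounds shown here, three have been measured so far in a physicochemical assay for acid dissociation. Compound 1 `NS(=O)(=O)c1ccc(S(=O)(=O)CCCO)c(F)c1` gives 9.02, compound 2 `NS(=O)(=O)c1ccc(SCCCCO)s1` gives 9.5, and compound 3 `CC(=O)OCCCCc1ccc(S(N)(=O)=O)cc1` gives 10.5. Compound 3 therefore stands highest of the three, and its gaps to compound 2 and to compound 1 both lie beyond the usual scatter of repeated measurements.

Compound 4 `CC(=O)OCCCCCc1ccc(S(N)(=O)=O)cc1` has not yet been measured. Its structural change from compound 3 is acetoxymethyl in place of acetoxy on a saturated chain carbon, four bonds along the chain from an aromatic carbon. In words, acetoxymethyl takes the place of acetoxy on a saturated chain carbon, four bonds along the chain from an aromatic carbon.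

Among the measured compounds shown here, no two measured compounds differ in just one place, so the data offer no direct guide to the size of this step. Compound 3, at 10.5, is the closest reference, and no step beyond the scatter is expected in this assay. The expected change is no change at the digits printed from compound 3 to compound 4 (within the scatter). The estimate for compound 4 is 10.5, with an expected range of 10.2 to 10.8.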

Compound 4, acid dissociation constant: 10.3
Estimate against measurement, compound 4: 0.20 log units above, within the range that was stated.
By their numbers in this assay, from the lowest: compound 1; then compound 2; then compounds 4 and 3 (each within the scatter of the next).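

Among the compounds shown here, this is the first pair here that differs in only one place, so it gives the first direct reading of a change on a saturated chain carbon, four bonds along the chain from an aromatic carbon. In this assay, acetoxymethyl in place of acetoxy gives a number 0.20 log units lower from compound 3 to compound 4 (within the scatter), so this read-out cannot tell the two compounds apart and this single change leaves no mark beyond the scatter. No measurement at hand explains this result.

Going by these compounds, it remains open whether an amine or a carboxylic acid at the end of the same chain would also stay within the scatter, or whether a longer chain, such as one ending in 2-acetoxyethyl, would do so. One pair also cannot show whether the same change would read alike on the core of compound 1 or of compound 2.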